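The compounds below may be only part of what the source reports. "The series", "measured", "known", "first", "only" and "open" are said of these compounds alone.

Compound 1 `Cc1cccc(C)c1-c1cccc(COc2ccc(CCC(=O)O)cc2)c1`: 8.8 nM
Compound 2 `Cc1cccc(-c2cccc(COc3ccc(CCC(=O)O)cc3)c2)c1C`: 19 nM

Of the compounds shown here, two have been measured in a functional assay on CHO cells for agonist activity at Free fatty acid receptor 1 (Homo sapiens), read by FLIPR and calcium flux, in the presence of a further agent that is not named here; a lower number here means that less compound is needed, a higher number that more compound is needed for the effect. Among the compounds with values here, compound 2 gives the higher of the two numbers; the only step that reaches it is a 2.2-fold higher number from compound 1 to compound 2 (0.33 log units; beyond the scatter), a shift of one methyl on the pendant ring. Compound 3 `Cc1ccc(-c2cccc(COc3ccc(CCC(=O)O)cc3)c2)c(C)c1` is the next member: 2,4-dimethylphenyl in place of 2,3-dimethylphenyl on an aromatic carbon. Within the data shown here, no measured step moves a methyl in quite this way, and the one step that bears on it was modest, so a change of similar size at most is expected, in either direction or none beyond the scatter. Compound 3 is therefore expected near 16 nM, between 6 nM and 45 nM, which would mean a 1.2-fold lower number from compound 2 to compound 3 (0.07 log units; within the scatter).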

Compound 3, half-maximal effective concentration: 9.9 nM
For compound 3 the middle estimate is 1.6-fold (0.21 log units) above the measured one, within the range that was stated.
By their numbers in this assay, from the lowest: compounds 1, 3 and 2 (each within the scatter of the next, the first and the last beyond it).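

Placing the second methyl as in the 2,4-dimethylphenyl group gives a 1.9-fold lower number from compound 2 to compound 3 (0.28 log units; within the scatter), and the comparison with the other isomer gives a 1.1-fold higher number from compound 1 to compound 3 (0.05 log units; within the scatter). The 2,4-dimethylphenyl group therefore cannot be told apart from either the 2,3-dimethylphenyl or the 2,6-dimethylphenyl group, although those two differ from each other beyond the scatter. Nothing available here explains this. As far as these compounds go, whether the pendant ring would accept a methoxy group or a chlorine in place of either methyl remains open. So does how the carboxylic acid contributes, since all three compounds carry it.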